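A few compounds are considered here, and "the series" means these few. Any claim that something is new, unique, unknown or untested is made for them only; others in the source may bear on it.

Compound 1 `CCNCC(=O)Nc1cc(OC)ccc1C(=O)c1ccc(OC)c2c1OC(C)(C)C=C2` and compound 2 `CCNCC(=O)Nc1cc(OC)ccc1C(=O)c1ccc(OC)c2c1C=CC(C)(C)O2` are built from the same atoms joined differently; the difference between their two cores is not broken down here. In a functional assay on HCT-8 cells (Homo sapiens) for antiproliferative activity, read by MTT assay, with a stated time of 48 h (a lower number here means a stronger inhibitor, a higher number a weaker inhibitor), compound 1 gives 3690 nM, while compound 2 gives 7890 nM, the highest of the three numbers measured. Compound 3 `COc1ccc(C(=O)c2ccc(OC)c3c2OC(C)(C)C=C3)c(NC(=O)CN(C)C)c1` differs from compound 1 by dimethylamino in place of ethylamino on a saturated chain carbon bound to a carbonyl carbon, and in this assay compound 3 gives 1590 nM, which makes a step of a 2.3-fold lower number from compound 1 to compound 3 (0.37 log units; beyond the scatter). Compound 4 `COc1ccc(C(=O)c2ccc(OC)c3c2C=CC(C)(C)O3)c(NC(=O)CN(C)C)c1` stands to compound 2 exactly as compound 3 stands to compound 1: the change is dimethylamino in place of ethylamino on a saturated chain carbon bound to a carbonyl carbon, made at the same place on the chain. For the measured compounds named here, only one example of this change has been measured, so the expectation for the core of compound 2 rests on that single step and nothing more. Going by the values given here, compound 4 is expected to show a step of a 2.3-fold lower number from compound 2 to compound 4 (0.37 log units; beyond the scatter), a size taken directly from a 2.3-fold lower number from compound 1 to compound 3 (0.37 log units; beyond the scatter), the one earlier example of this change. Compound 4 is accordingly estimated at 3400 nM in this assay, with a plausible range from 1500 nM to 8000 nM.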

Compound 4, half-maximal inhibitory concentration: 5660 nM
Compound 4: middle estimate off by 1.7-fold (0.22 log units), on the low side; the range from low to high includes it.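

In this assay, putting dimethylamino in place of ethylamino on the core of compound 2 gives a 1.4-fold lower number from compound 2 to compound 4 (0.14 log units; within the scatter), a step that cannot be told apart from repeat measurement on this core. Compared with the same change on the core of compound 1, the size of the step cannot be said to depend on the core: the same change on two cores in this assay, a 2.3-fold lower number (0.37 log units; beyond the scatter) from compound 1 to compound 3 and a 1.4-fold lower number (0.14 log units; within the scatter) from compound 2 to compound 4, 1.7-fold (0.22 log units) apart, within the scatter of two such steps. For the compounds shown here, this shows only that the two steps agree within the noise of the assay; it does not show that the change has the same size on both cores, since only one of the two steps stands clear of the scatter, and two pairs say nothing about any further core.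

The compounds shown leave open how a primary amine, diethylamino or a ring amine such as pyrrolidine or morpholine would compare on either core. They also leave open what a longer chain carrying the amine would do in this assay.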